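This account rests on a few compounds, and the source may have more. Where it says the series, first, only, none or still open, it means among the compounds named here.

Working notes on the series. In a functional assay on MIA PaCa-2 cells (Homo sapiens) for antiproliferative activity (on this read-out lower numbers stand for an effect already at smaller amounts and higher numbers for an effect only at larger amounts of compound), compound 2 (`Cc1cc2c(C(=O)NCCC#N)cccc2n1-c1nc2c(c(NCc3ccccc3)n1)CCCC2`) gives 517 nM, which cannot be told apart from compound 3 (`CC#CCNC(=O)c1cccc2c1cc(C)n2-c1nc2c(c(NCc3ccccc3)n1)COCC2`) at 524 nM. Compound 1 (`Cc1cc2c(C(N)=O)cccc2n1-c1nc2c(c(NCc3ccccc3)n1)COCC2`) gives a lower number, 146 nM.

Compound 4 (`C=CC#CC(=O)Nc1cccc2c1cc(C)n2-c1nc2c(c(NCc3ccccc3)n1)CCCC2`) is related to compound 2 by a group of 7 heavy atoms (5 carbon, 1 nitrogen, 1 oxygen; no ring) in place of a group of 7 heavy atoms (4 carbon, 2 nitrogen, 1 oxygen; no ring), on an aromatic carbon: the (2-cyanoethyl)carbamoyl group leaves and a group with no common name enters, on an aromatic carbon.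

Among the measured compounds shown here, no measured step covers this exchange. The nearest is a 3.6-fold higher number from compound 1 to compound 3 (0.55 log units; beyond the scatter), with but-2-yn-1-yl in place of hydrogen on an amide-type nitrogen, and it is modest. For the measured compounds named here, compound 2 and compound 3 differ in more than one place, yet their values stay together, so the single measured step gives no direction for the new group. No step beyond the scatter is therefore expected in this assay, though with little confidence. The expected change is a 1.2-fold higher number from compound 2 to compound 4 (0.06 log units; within the scatter). For compound 4 the estimated value is 600 nM, with an expected range of 150 nM to 2500 nM.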

Compound 4, half-maximal effective concentration: 892 nM
Estimate against measurement, compound 4: 1.5-fold (0.17 log units) below; the range from low to high includes it.
By their numbers in this assay, from the lowest: compound 1; then compounds 2, 3 and 4 (each within the scatter of the next).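

In this assay the exchange on this aromatic carbon, with the (2-cyanoethyl)carbamoyl group leaving and a group with no common name entering, reads as a 1.7-fold higher number from compound 2 to compound 4 (0.24 log units; within the scatter). Among the compounds shown here, the only earlier step lay on an amide-type nitrogen, so this is the first reading of a whole-group exchange at this position, and it shows that a second double bond outside aromatic rings and one hydrogen-bond acceptor in place of two come with no step beyond the scatter. No supporting measurement bears on why the two groups read this way.

As far as these compounds go, whether an amine, a carboxylic acid or a longer chain on this carbon would step beyond the scatter stays open. Also open, from the compounds shown here alone, is whether the same exchange reads alike on the core of compound 1, which gives 146 nM.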